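This account rests on a few compounds, and the source may have more. Where it says the series, first, only, none or still open, it means among the compounds named here.

Measured so far in a functional assay on RAW264.7 cells (Mus musculus) for inhibition, with a stated time of 30 min; a lower number here means a stronger inhibitor, a higher number a weaker inhibitor: compound 1 `C=C1C(=O)OC[C@@H]1CCOC(=O)Nc1ccc(F)cc1F` gives 700 nM; compound 2 `C=C1C(=O)OC[C@H]1CCOC(=O)Nc1ccc(C(=O)OCCCC)cc1` gives 430 nM; compound 3 `C=C1C(=O)OC[C@@H]1CCOC(=O)Nc1ccc(C(=O)OCCCC)cc1` gives 860 nM.

Compound 2 is the reference point, but its gaps to compound 1 and to compound 3 both fall within the scatter, so the three numbers are not separated. Among the compounds with values here, the only single-point step available, a 2.0-fold higher number from compound 2 to compound 3 (0.30 log units; within the scatter), is within the scatter and rests on the fact that compounds 2 and 3 differ only in the configuration as drawn alone; it says nothing about substituents on the aromatic ring.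

Compound 4 `C=C1C(=O)OC[C@H]1CCOC(=O)Nc1ccc(CC)cc1` keeps the configuration of compound 2 and carries ethyl in place of butoxycarbonyl on an aromatic carbon. Within the data shown here, no measured step covers an exchange of this kind, so the expectation rests on the unchanged core only: the step of a 1.4-fold higher number from compound 2 to compound 4 (0.14 log units; within the scatter) is expected to stay within the scatter. Compound 4 is therefore estimated at 600 nM, with a range of 250 nM to 1500 nM in this assay.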

Compound 4, half-maximal inhibitory concentration: 840 nM
The estimate for compound 4 lay 1.4-fold (0.15 log units) below the measured number; low and high end bracket the measured number.
By their numbers in this assay, from the lowest: compounds 2, 1, 4 and 3 (each within the scatter of the next).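

In this assay, the exchange of butoxycarbonyl for ethyl on this aromatic carbon gives a 2.0-fold higher number from compound 2 to compound 4 (0.29 log units; within the scatter), the first substituent exchange read at this position on an unchanged configuration. The substituent's hydrogen-bond acceptors and most of its heavy atoms can therefore go without a step beyond the scatter. Nothing available bears on why the number responds in this way.

From the compounds shown here alone, whether an amine, a carboxylic acid or a longer alkyl chain at this position would give a step beyond the scatter remains open. Also open, going by these compounds, is whether ethyl behaves the same way on the opposite drawn configuration.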